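Halogen rearrangement on the sulfonamide aryl ring

This account rests on a few compounds, and the source may have more. Where it says the series, first, only, none or still open, it means among the compounds named here.

Three compounds share one core and differ only in the aryl group on the sulfonamide nitrogen. In an assay on isolated protein for binding affinity to 5-hydroxytryptamine receptor 6 (Homo sapiens) (a higher number here means a weaker inhibitor, a lower number a stronger inhibitor), compound 1 `COc1ccc(S(=O)(=O)Nc2cccc(Br)c2)cc1N1CCNCC1` gives 1.26 nM, and compound 2 `COc1ccc(S(=O)(=O)Nc2cccc(I)c2)cc1N1CCNCC1` gives 0.501 nM, the two separated by a 2.5-fold lower number from compound 1 to compound 2 (0.40 log units; beyond the scatter). Compound 3 `COc1ccc(S(=O)(=O)Nc2c(F)cc(Br)cc2F)cc1N1CCNCC1` gives 158 nM, the highest of the three numbers: a 130-fold higher number from compound 1 to compound 3 (2.10 log units; beyond the scatter) and a 320-fold higher number from compound 2 to compound 3 (2.50 log units; beyond the scatter).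

Compound 4 `COc1ccc(S(=O)(=O)Nc2cc(Br)cc(Cl)c2Cl)cc1N1CCNCC1` is not yet measured. It differs from compound 3 in one place: 5-bromo-2,3-dichlorophenyl in place of 4-bromo-2,6-difluorophenyl on a sulfonamide nitrogen. The bromo thus moves back toward the arrangement seen in compound 1 and compound 2, while two chloro groups replace the two fluoro groups. For the measured compounds named here, the two large steps onto compound 3 suggest that leaving the 4-bromo-2,6-difluorophenyl pattern could return a good part of what was lost, yet no measured pair isolates the chloro positions, so the expectation is broad. Compound 4 is therefore expected to show a lower number than compound 3, by a 7.9-fold lower number from compound 3 to compound 4 (0.90 log units; beyond the scatter), while still likely sitting above compound 1. The estimate for compound 4 in this assay is 20 nM, with a range from 2 nM to 200 nM.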

Compound 4, inhibition constant: 3.98 nM
Compound 4: middle estimate off by 5.0-fold (0.70 log units), on the high side; low and high end bracket the measured number.
By their numbers in this assay, from the lowest: compound 2; then compound 1; then compound 4; then compound 3.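

In this assay, the 5-bromo-2,3-dichlorophenyl group of compound 4 recovers most of the loss seen with compound 3, with a 40-fold lower number from compound 3 to compound 4 (1.60 log units; beyond the scatter). A sulfonamide nitrogen can therefore carry an aryl group with bromo and two further halogens and still give a low number, so the high number of compound 3 is not shared by every such aryl group among these compounds. The simpler aryl groups still keep an edge, with a 3.2-fold higher number from compound 1 to compound 4 (0.50 log units; beyond the scatter) and a 7.9-fold higher number from compound 2 to compound 4 (0.90 log units; beyond the scatter). No supporting evidence bears on why these numbers differ.

The place of the bromo and the exchange of fluoro for chloro change together from compound 3 to compound 4, so their separate shares in the step stay unresolved. Also open, on these data alone, is how a methoxy or an amine on this aryl group would compare.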